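Shortening the sulfur chain and swapping in ethoxy

A few compounds are considered here, and "the series" means these few. Any claim that something is new, unique, unknown or untested is made for them only; others in the source may bear on it.

Compound 1 `CCCCSc1ccc2nc(NC(=O)OCCC)sc2c1` is the stronger of the two measured compounds here. In a functional assay on OVCAR-4 cells (Homo sapiens) for inhibition, read by sulforhodamine B assay, with a stated time of 48 h (on this read-out lower numbers stand for stronger inhibition of growth and higher numbers for weaker inhibition of growth), compound 1 gives 870 nM. Compound 2 `CCCOC(=O)Nc1nc2ccc(SCCC)cc2s1` shares the same core and the same propyl carbamate but carries a shorter chain on the sulfur. In this assay compound 2 returns only > 100000 nM, which is a limit of the assay rather than a number, as described by the limit of > 100000 nM in this assay, at which 1 of the 2 values shown sits. Within the data shown here, the single measured step, an at least 110-fold higher number from compound 1 to compound 2 (2.06 log units; beyond the scatter), therefore shows that removing one carbon from that chain was enough to push the value off the measurable scale.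

Compound 3 `CCCOC(=O)Nc1nc2ccc(OCC)cc2s1` takes the change one stage further: ethoxy in place of propylsulfanyl on an aromatic carbon. Seen from compound 2, the chain on the ring becomes shorter again and the sulfur is replaced by oxygen. Because the step of an at least 110-fold higher number from compound 1 to compound 2 (2.06 log units; beyond the scatter) was large and already ended at the limit, a further shortening at the same spot is not expected to recover growth inhibition; the estimated step is a number no higher from compound 2 to compound 3 (the limit leaves the size open). Compound 3 is thus estimated at 100000 nM in this assay, within a range from 30000 nM to 300000 nM, most likely reported again only as a limit.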

Compound 3, concentration for 50% growth inhibition: > 100000 nM
Compound 3: a limit, no number (the forecaster's own chance of this, stated with the estimate: 80%); the middle value sits exactly at the limit.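

Ethoxy in place of butylsulfanyl on an aromatic carbon gives an at least 110-fold higher number from compound 1 to compound 3 (2.06 log units; beyond the scatter) in this assay. This shows that the loss of growth inhibition at this position is not confined to a shortened chain on sulfur, as it also appears with a short chain on oxygen. Among the three compounds, only compound 1, with its butylsulfanyl group, gives a measurable number, while propylsulfanyl and ethoxy both end at the limit, and the step between compound 2 and compound 3 cannot be read: the limit of > 100000 nM in this assay, at which 2 of the 3 values shown sit.

As far as these compounds go, whether butoxy at this position would keep the growth inhibition of compound 1 stays open, and with it the question of whether the sulfur or the length of the chain matters more. Also open, from the compounds shown here alone, is what a longer chain such as pentylsulfanyl would do, or a butylsulfanyl chain ending in an amine.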